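Swapping Difluoromethoxy for Chloro on the Sulfonamide Aryl Ring

The source may report more compounds than this note shows. Statements on the series, on what has been measured and on what is new or still open speak of the compounds shown alone.

Of the compounds shown here, three built on one shared core have been tested in a functional assay on M21 cells (Homo sapiens) for antiproliferative activity, read by sulforhodamine B assay, with a stated time of 48 h; a higher number here means a weaker inhibitor, a lower number a stronger inhibitor. Compound 1 `O=C1NCCN1c1ccc(S(=O)(=O)Nc2ccc(OC(F)F)cc2)cc1` gives 410 nM, while compound 3 `O=C1NCCN1c1ccc(S(=O)(=O)Nc2ccccc2)cc1` gives 200 nM. Compound 2 `CCCCCCOc1ccc(NS(=O)(=O)c2ccc(N3CCNC3=O)cc2)cc1` reaches only the limit of > 1000 nM in this assay, so it yields no number. Among the two real numbers, compound 1 stands highest, and its nearest neighbour is compound 3, reached by the step of a 2.1-fold lower number from compound 1 to compound 3 (0.31 log units; beyond the scatter).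

Compound 4 `O=C1NCCN1c1ccc(S(=O)(=O)Nc2ccc(Cl)cc2)cc1` differs from compound 1 by chloro in place of difluoromethoxy on an aromatic carbon. Within the data shown here, two measured steps bear on this change: a 2.1-fold lower number from compound 1 to compound 3 (0.31 log units; beyond the scatter), where losing the difluoromethoxy group lowered the number, and an at least 2.4-fold higher number from compound 1 to compound 2 (0.38 log units; beyond the scatter), where a hexyl chain on the same oxygen raised it past the limit. Chloro enters as a single heavy atom, nearer to the bare hydrogen of compound 3 than to either oxygen-bearing group, so a step of a 1.6-fold lower number from compound 1 to compound 4 (0.20 log units; within the scatter) toward a lower number is expected. Compound 4 is therefore estimated at 260 nM, with a likely range from 120 nM to 600 nM.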

Compound 4, half-maximal inhibitory concentration: 90 nM
For compound 4 the middle estimate is 2.9-fold (0.46 log units) above the measured one; the measured number lies below the stated range.
By their numbers in this assay, from the lowest: compound 4; then compound 3; then compound 1. At a limit, above all of these: compound 2.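

Among these compounds, at this position on the aromatic ring, a substituent can do better than bare hydrogen: chloro in place of hydrogen lowers the number (a 2.2-fold lower number from compound 3 to compound 4 (0.35 log units; beyond the scatter)), whereas the earlier steps showed only a lower number when an oxygen-bearing group was removed. Chloro in place of difluoromethoxy gives a larger change (a 4.6-fold lower number from compound 1 to compound 4 (0.66 log units; beyond the scatter)), and compound 4 shows that the number does not simply rise with the count of heavy atoms on this carbon, since bare hydrogen in compound 3 does not give the lowest number. The step from the hexyloxy compound (an at least 11-fold lower number from compound 2 to compound 4 (1.04 log units; beyond the scatter)) is only a bound, as compound 2 stands at a limit: the limit of > 1000 nM in this assay, at which 1 of the 4 values shown sits.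

On these data alone, whether bromo, methyl or an amine on this carbon would lower the number further remains open. The compounds shown give no reason why chloro lowers it.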